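A few compounds are considered here, and "the series" means these few. Any claim that something is new, unique, unknown or untested is made for them only; others in the source may bear on it.

Measured so far:
compound 1 `COc1cccc(/C=N/Nc2ncc3c(n2)n(C2CCCC2)c(=O)c(=O)n3C)c1` — 45800 nM
compound 2 `Cn1c(=O)c(=O)n(C2CCCC2)c2nc(N/N=C/c3ccco3)ncc21` — 78700 nM
compound 3 `Cn1c(=O)c(=O)n(C2CCCC2)c2nc(N/N=C/c3cc(C(F)(F)F)cc(C(F)(F)F)c3)ncc21` — 4360 nM

In a functional assay on HCT-116 cells (Homo sapiens) for antiproliferative activity, read by MTT assay (a higher number here means a weaker inhibitor, a lower number a stronger inhibitor), compound 2 gives the highest of the three numbers. Its nearest neighbour is compound 1, and the step of a 1.7-fold higher number from compound 1 to compound 2 (0.24 log units; within the scatter) lies within the scatter. Within the data shown here, compound 3 stands far lower, and the gap between compound 2 and compound 3 is beyond the scatter; no single-change step links the two.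

Compound 4 `Cn1c(=O)c(=O)n(C2CCCC2)c2nc(N/N=C/c3ccc(O)c(Br)c3)ncc21` differs from compound 2 by 3-bromo-4-hydroxyphenyl in place of furan-2-yl on a carbon with a double bond to nitrogen. Among the measured compounds shown here, no measured step covers this exact exchange. The step from compound 1 to compound 2 shows that a six-membered carbon ring and furan-2-yl at this carbon give numbers within the scatter of each other, while compound 3 shows that a more heavily substituted phenyl can bring a much lower number. A moderate drop in this assay is therefore expected, roughly a 3.9-fold lower number from compound 2 to compound 4 (0.59 log units; beyond the scatter). Compound 4 is estimated at 20000 nM, with a range of 5000 nM to 60000 nM.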

Compound 4, half-maximal inhibitory concentration: 17700 nM
Beside the measured number, compound 4's estimate is 1.1-fold (0.05 log units) above it; the range from low to high includes it.
By their numbers in this assay, from the lowest: compound 3; then compound 4; then compounds 1 and 2 (each within the scatter of the next).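

In this assay the change from furan-2-yl to 3-bromo-4-hydroxyphenyl on this carbon gives a 4.4-fold lower number from compound 2 to compound 4 (0.65 log units; beyond the scatter) and the change from 3-methoxyphenyl to the same group gives a 2.6-fold lower number from compound 1 to compound 4 (0.41 log units; beyond the scatter) as a second modest step. Unlike the exchange of 3-methoxyphenyl for furan-2-yl, both single changes lie beyond the scatter, so the number at this carbon does respond to the group placed there. Nothing available bears on why the number moves. Going by these compounds, the separate shares of the bromine and the hydroxyl remain open, since both enter together. Also open, on these data alone, is how an amine or a carboxylic acid on the phenyl ring would read here.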